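A Methyl Ester Change Carried Over to a Second Core

The source may report more compounds than this note shows. Statements on the series, on what has been measured and on what is new or still open speak of the compounds shown alone.

Of the compounds shown here, three have been measured in an assay for inhibition of Fatty-acid amide hydrolase 1 (Rattus norvegicus); on this read-out higher numbers stand for weaker inhibition and lower numbers for stronger inhibition. Compound 1 `COC(=O)c1cc(-c2cnc(C(=O)CCc3ccc(-c4ccccc4)cc3)o2)ccn1` gives 1.5 nM. Compound 3 `O=C(O)c1cc(-c2cnc(C(=O)CCc3ccc(-c4ccccc4)cc3)o2)ccn1` gives 50 nM, and compound 2 `O=C(O)c1cccc(-c2cnc(C(O)CCc3ccc(-c4ccccc4)cc3)o2)n1` gives 1100 nM, the highest number of the three. The change from compound 3 to compound 1 is methyl in place of hydrogen on an oxygen next to a carbonyl group and it produced a 33-fold lower number from compound 3 to compound 1 (1.52 log units; beyond the scatter).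

Compound 4 `COC(=O)c1cccc(-c2cnc(C(O)CCc3ccc(-c4ccccc4)cc3)o2)n1` has not yet been measured. It relates to compound 2 through (methyl in place of hydrogen on an oxygen next to a carbonyl group), the same change that separates compound 3 from compound 1, at a place described in the same words for both pairs. Seen one bond further out, however, the change reads 6-carboxypyridin-2-yl to 6-(methoxycarbonyl)pyridin-2-yl in the pair of compound 2 and compound 4, against 2-carboxypyridin-4-yl to 2-(methoxycarbonyl)pyridin-4-yl in the pair of compound 3 and compound 1. The difference between the two cores, that of compound 2 and that of compound 3, is not broken down here.

Within the data shown here, with only one earlier instance of the change, and with the cores differing in more than one place, the transfer is uncertain. The step from compound 2 to compound 4 in this assay is expected to be a 24-fold lower number from compound 2 to compound 4 (1.39 log units; beyond the scatter), resting on the measured step of a 33-fold lower number from compound 3 to compound 1 (1.52 log units; beyond the scatter), but taken with caution because compound 2 gives 1100 nM, a number that sits far from the other two. Compound 4 is estimated at 45 nM, with a likely span from 10 nM to 250 nM.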

Compound 4, inhibition constant: 9000 nM
For compound 4 the middle estimate is 200-fold (2.30 log units) below the measured one; measured number outside the range, above it.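

In this assay, the methyl ester did not repeat on the second core what it had done on the first; methyl in place of hydrogen on the oxygen of the carboxy group gave an 8.2-fold higher number from compound 2 to compound 4 (0.91 log units; beyond the scatter). The same change therefore moved the read-out in opposite directions on the two cores, and in this series its result on one core did not carry over to the other: the same change on two cores in this assay, a 33-fold lower number (1.52 log units; beyond the scatter) from compound 3 to compound 1 and an 8.2-fold higher number (0.91 log units; beyond the scatter) from compound 2 to compound 4, 270-fold (2.44 log units) apart, beyond the scatter of two such steps. This does not show which feature of the cores goes with the reversal, since they differ in more than one place and no pair shown separates those differences, and two instances of the change are too few to support a general rule.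

The compounds shown leave open whether the reversal follows the 6-carboxypyridin-2-yl arrangement as against the 2-carboxypyridin-4-yl one, or the other difference between the two cores. They also leave open how an ethyl ester or a primary amide in place of the methyl ester would behave on either core, and so whether the opposite steps are particular to the methyl ester or extend to other replacements of the carboxy group.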